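The source may report more compounds than this note shows. Statements on the series, on what has been measured and on what is new or still open speak of the compounds shown alone.

Measured so far in a functional assay on ECa-109 cells for inhibition, with ECa-109 cell line (Homo sapiens) as the target, read by sulforhodamine B assay; a higher number here means a weaker inhibitor, a lower number a stronger inhibitor:

- Compound 1 `CCOc1ccc(NC2=CC(=O)c3c(nc4n3[C@H]3OC[C@@H](O)[C@H]3OC4)C2=O)cc1` gives > 4000 nM, which is a limit of the assay rather than a number.
- Compound 2 `COc1cccc(NC2=CC(=O)c3nc4n(c3C2=O)[C@H]2OC[C@@H](O)[C@H]2OC4)c1` gives 7620 nM.
- Compound 3 `O=C1C(NC2CCCCC2)=CC(=O)c2c1nc1n2[C@H]2OC[C@@H](O)[C@H]2OC1` gives > 16000 nM, again a limit rather than a number.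

Compound 3 therefore sits at the high end of what is shown, at the limit of > 16000 nM in this assay, at which 1 of the 3 values shown sits, and only a limit is known for it. Compound 1 sits at the limit of > 4000 nM in this assay, at which 1 of the 3 values shown sits. The one step that joins two of these compounds in a single change, a step that the two limits leave unreadable from compound 1 to compound 3, cannot be read in size, since both of its ends are limits.

Compound 4 `O=C1C(Nc2cccc(F)c2)=CC(=O)c2c1nc1n2[C@H]2OC[C@@H](O)[C@H]2OC1` differs from compound 3 by 3-fluorophenyl in place of cyclohexyl on an amine nitrogen. For the measured compounds named here, no measured step reads this change directly. What is known is that the two compounds carrying an aryl group on the amine nitrogen, compound 1 and compound 2, are weak, with compound 2 giving a number of 7620 nM in this assay. A 3-fluorophenyl on the same nitrogen is expected to land in the same weak region. The step of an at least 2.0-fold lower number from compound 3 to compound 4 (0.30 log units; that floor lies within the scatter) is therefore expected to be small or unreadable. Compound 4 is estimated at 8000 nM, within a range from 2500 nM to 25000 nM.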

Compound 4, half-maximal inhibitory concentration: 2370 nM
Compound 4: middle estimate off by 3.4-fold (0.53 log units), on the high side; the whole stated range lies above it.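

In this assay, for the compounds shown here, the change on the amine nitrogen from cyclohexyl to 3-fluorophenyl gives an at least 6.7-fold lower number from compound 3 to compound 4 (0.82 log units; beyond the scatter), the first step at this position whose size can be read, and it shows that the group held there does affect the result. Compound 3 is known only as a limit, which makes that step a floor rather than an exact size: the limit of > 16000 nM in this assay, at which 1 of the 4 values shown sits. The change between two aromatic groups at the same position gives an at least 1.6-fold lower number from compound 1 to compound 4 (0.22 log units; that floor lies within the scatter), so this pair does not yet show that 3-fluorophenyl differs from 4-ethoxyphenyl.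

Compound 1 is likewise known only as a limit, which leaves the real gap on that step open: the limit of > 4000 nM in this assay, at which 1 of the 4 values shown sits. It also remains unclear whether the gain in the step from cyclohexyl depends on the fluorine or on the aromatic ring alone, a question that a plain phenyl on the same nitrogen could answer, while a 4-fluorophenyl could show whether the fluorine's place on the ring matters.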